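A Larger Amine Replaces Dimethylamino in Compound 2

The compounds below may be only part of what the source reports. "The series", "measured", "known", "first", "only" and "open" are said of these compounds alone.

Two compounds carry the shared ester and a second aromatic ring at different positions of the core. Compound 1 `CCOC(=O)c1ccnc(-c2ccc(OCC)cc2)c1` gives 87% in an assay on COS-7 cells for inhibition of patatin-like phospholipase domain-containing protein 2 (Mus musculus), tested at 200 uM; on this read-out lower numbers stand for less inhibition and higher numbers for more inhibition at the one concentration tested (going by the name of the read-out). Compound 2 `CCOC(=O)c1cccc(-c2ccc(CN(C)C)o2)c1` gives 53% in this assay, the lowest of the two numbers, with compound 1 standing higher by a margin beyond the usual scatter. The two compounds differ in more than one place, so only the two values themselves can be compared.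

Compound 3 `CCOC(=O)c1cccc(-c2ccc(CN3CCN(C)CC3)o2)c1` is not yet measured. It differs from compound 2 in a single place: 4-methylpiperazin-1-yl in place of dimethylamino on a saturated chain carbon bound to an aromatic carbon. Within the data shown here, no measured pair reports what this change does, so the expectation rests on compound 2 alone. A step of a number 2 percentage points higher from compound 2 to compound 3 (within the scatter) is expected, small enough that it may fall within the usual scatter, so that the number may come out higher, lower or level. Because compound 2 gives 53% in this assay, compound 3 is estimated at 55%, with a range from 35% to 75%.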

Compound 3, a percentage reported as inhibition, at one concentration (the size of the read-out at that concentration, not a potency): 67%
Compound 3: middle estimate off by 12 percentage points, on the low side; the range from low to high includes it.
By their numbers in this assay, from the lowest: compound 2; then compound 3; then compound 1.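

In this assay, among these compounds, 4-methylpiperazin-1-yl in place of dimethylamino on a saturated chain carbon bound to an aromatic carbon gives a number 14 percentage points higher from compound 2 to compound 3 (beyond the scatter) and so provides the first reading of a change at this place. It shows that this place accepts a larger amine, one carrying a six-membered non-aromatic ring with 2 hetero atoms, with no loss and indeed a modest gain in inhibition at the one concentration tested. Nothing available explains the rise, and this one step changes the size of the amine, the ring and the count of nitrogens together.

What remains open is which of these features accounts for the step, a question that piperidin-1-yl, morpholin-4-yl or piperazin-1-yl without its methyl group at the same place could help to separate. Also unsettled are whether the same exchange gives a similar step on the core of compound 1 and whether the gain at a single concentration would carry over to a measured potency.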